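The source may report more compounds than this note shows. Statements on the series, on what has been measured and on what is new or still open speak of the compounds shown alone.

In a functional assay on DU-145 cells (Homo sapiens) for inhibition, read by WST assay, with a stated time of 3 days (a lower number here means a stronger inhibitor, a higher number a weaker inhibitor), three compounds share one core and differ only in the straight chain on an aromatic nitrogen. Compound 1 `CCn1ccnc1/C=C/C(=O)/C=C/c1coc2ccccc2c1=O` gives 3000 nM, compound 2 `CCCn1ccnc1/C=C/C(=O)/C=C/c1coc2ccccc2c1=O` gives 4600 nM and compound 3 `CCCCCn1ccnc1/C=C/C(=O)/C=C/c1coc2ccccc2c1=O`, which carries pentyl, gives 2700 nM. Compound 3 therefore stands level with the other two, and its number cannot be separated from theirs.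

The next structure, compound 4 `CCCC(C)n1ccnc1/C=C/C(=O)/C=C/c1coc2ccccc2c1=O`, has the same atoms as compound 3, joined differently: 1-methylbutyl in place of pentyl on an aromatic nitrogen. Here 1-methylbutyl takes the place of pentyl on an aromatic nitrogen of the five-membered ring, next to the ring atom that bears a large group.

The closest evidence comes from the measured changes to this chain, which gave a 1.5-fold higher number from compound 1 to compound 2 (0.19 log units; within the scatter), a 1.1-fold lower number from compound 1 to compound 3 (0.05 log units; within the scatter) and a 1.7-fold lower number from compound 2 to compound 3 (0.23 log units; within the scatter). All three steps are small, but each only extends a straight chain, so none of them tests 1-methylbutyl directly. With that gap in mind, no step beyond the scatter is expected in this assay, although the range has to stay fairly wide. The expected change is a 1.1-fold higher number from compound 3 to compound 4 (0.05 log units; within the scatter). For compound 4 the estimated value is 3000 nM, with an expected range from 1300 nM to 7000 nM.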

Compound 4, half-maximal inhibitory concentration: 1400 nM
For compound 4 the middle estimate is 2.1-fold (0.33 log units) above the measured one; the measured number falls inside the stated range.
By their numbers in this assay, from the lowest: compounds 4, 3, 1 and 2 (each within the scatter of the next, the first and the last beyond it).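

In this assay, 1-methylbutyl in place of pentyl on the aromatic nitrogen gives a 1.9-fold lower number from compound 3 to compound 4 (0.29 log units; within the scatter) and so rearranging the same atoms into a branched chain produces no change that can be separated from ordinary assay variation. Even so, the branched chain opens the first gaps at this position that lie beyond the scatter, with a 3.3-fold lower number from compound 2 to compound 4 (0.52 log units; beyond the scatter) and a 2.1-fold lower number from compound 1 to compound 4 (0.33 log units; beyond the scatter) as modest steps, whereas the straight chains in compounds 1, 2 and 3 all remain within the scatter of one another. Nothing measured here explains why these gaps appear, so their cause remains unknown.

Compound 4 therefore hints that a branched chain at this nitrogen may be tolerated, but it cannot show that branching itself helps, as it stays within the scatter of compound 3. The compounds shown leave open how a shorter branched chain such as isopropyl, a ring such as cyclopentyl, or a chain ending in an amine or a carboxylic acid would behave at this same nitrogen.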